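Removing a methoxy group: compound 3 to compound 4

The source may hold more compounds than are shown below. What is called first, only, known or untested is meant among the compounds shown, and "the series" means these compounds.

Compound 3 `COc1ccc(/C=C/C(=O)Nc2cc3c(Nc4ccc(F)c(Cl)c4)ncnc3cc2O[C@H]2CCOC2)c(OC)c1` carries the 2,4-dimethoxyphenyl group and gives 28600 nM in a functional assay on MCF7 cells (Homo sapiens) for cytotoxicity, read by MTT assay, with a stated time of 72 h; a higher number here means a weaker inhibitor, a lower number a stronger inhibitor. Among the three measured compounds it holds the second highest number: compound 1 `COc1cc(/C=C/C(=O)Nc2cc3c(Nc4ccc(F)c(Cl)c4)ncnc3cc2O[C@H]2CCOC2)cc(OC)c1O` gives 30500 nM and lies within the scatter of compound 3, whereas compound 2 `COc1ccc(/C=C/C(=O)Nc2cc3c(Nc4ccc(F)c(Cl)c4)ncnc3cc2O[C@H]2CCOC2)c(OC)c1OC` gives 4650 nM and is clearly the stronger one, as the step of a 6.2-fold higher number from compound 2 to compound 3 (0.79 log units; beyond the scatter) shows.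

Compound 4 `COc1ccc(/C=C/C(=O)Nc2cc3c(Nc4ccc(F)c(Cl)c4)ncnc3cc2O[C@H]2CCOC2)cc1` differs from compound 3 by hydrogen in place of methoxy on an aromatic carbon, ortho to a large group and meta to a methoxy group, so that 2,4-dimethoxyphenyl becomes 4-methoxyphenyl.

For the measured compounds named here, two measured steps bear on this. Going by the values given here, the closest precedent is the loss of one methoxy group on the same six-membered aromatic ring, a 6.2-fold higher number from compound 2 to compound 3 (0.79 log units; beyond the scatter), which raised the number beyond the scatter. The rearrangement of methoxy groups in a 1.1-fold lower number from compound 1 to compound 3 (0.03 log units; within the scatter) left the number unchanged. Taking away a further methoxy group is therefore expected to leave the number where it is or push it somewhat higher; a gain is not expected. Compound 4 is estimated at 45000 nM, between 15000 nM and 130000 nM, corresponding to an expected step of a 1.6-fold higher number from compound 3 to compound 4 (0.20 log units; within the scatter) in this assay. Among the compounds with values here, only three measured compounds support this, so the range is kept wide.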

Compound 4, half-maximal inhibitory concentration: 5070 nM
Compound 4: middle estimate off by 8.9-fold (0.95 log units), on the high side, outside the stated range (below it).
By their numbers in this assay, from the lowest: compounds 2 and 4 (each within the scatter of the next); then compounds 3 and 1 (each within the scatter of the next).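

In this assay, replacing methoxy by hydrogen on the aromatic carbon ortho to a large group gives a 5.6-fold lower number from compound 3 to compound 4 (0.75 log units; beyond the scatter), opposite in direction to the earlier loss of a methoxy group, a 6.2-fold higher number from compound 2 to compound 3 (0.79 log units; beyond the scatter). Across compounds 2, 3 and 4, the same kind of change therefore has no single direction, and its outcome depends on the aromatic carbon involved or the other groups on the ring. The step of a 1.1-fold higher number from compound 2 to compound 4 (0.04 log units; within the scatter) lies within the scatter, so 4-methoxyphenyl and 2,3,4-trimethoxyphenyl cannot be separated here, while a 6.0-fold lower number from compound 1 to compound 4 (0.78 log units; beyond the scatter) shows that 4-methoxyphenyl also differs from 4-hydroxy-3,5-dimethoxyphenyl beyond the scatter, leaving 2,4-dimethoxyphenyl and 4-hydroxy-3,5-dimethoxyphenyl as the two groups with the higher numbers. No measurement at hand explains this reversal.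

The compounds shown do not tell whether the remaining methoxy group of 4-methoxyphenyl matters, which an unsubstituted phenyl group, an amine or a carboxylic acid in its place would test. They also leave open whether the methoxy group ortho to a large group raises the number on its own, as a 2-methoxyphenyl group would show.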